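This account rests on a few compounds, and the source may have more. Where it says the series, first, only, none or still open, it means among the compounds named here.

Among the three compounds measured in a functional assay on MT4 cells (Homo sapiens) for cytotoxicity (on this read-out higher numbers stand for lower toxicity in this test and lower numbers for higher toxicity in this test), compound 1, `Cc1nc(S)n(Nc2cccc(Cl)c2)c1-c1ccc(Cl)cc1`, gives 40800 nM, which is the lowest of the three numbers and therefore marks the most toxic member in this test; its steps to both other compounds lie beyond the scatter. Compound 2, `CC1N=CN(Nc2ccccc2)C1C`, gives 351000 nM in this assay, and compound 3, `Cc1cccc(NN2C(S)=NC(C)C2C)c1`, gives 360000 nM. Compounds 2 and 3 lack the halogen-bearing aryl groups of compound 1 and differ from it in more than one place, so their numbers say only that both sit far above compound 1.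

Compound 4, `Cc1nc(S)n(Nc2cccc(Cl)c2)c1-c1ccc(Br)cc1`, differs from compound 1 by bromo in place of chloro on an aromatic carbon. Going by the values given here, no measured pair in this set shows a chloro-to-bromo exchange, so the size of that step is unknown here. A single heavy-atom swap of this kind would be expected to shift cytotoxicity by little, if at all beyond the scatter, with a slight lean toward a lower number. The step from compound 1 to compound 4 is estimated as a 1.2-fold lower number from compound 1 to compound 4 (0.07 log units; within the scatter). Compound 4 is thus expected to give about 35000 nM in this assay, within a range from 15000 nM to 90000 nM.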

Compound 4, half-maximal cytotoxic concentration: 33200 nM
Beside the measured number, compound 4's estimate is 1.1-fold (0.02 log units) above it; the range from low to high includes it.
By their numbers in this assay, from the lowest: compounds 4 and 1 (each within the scatter of the next); then compounds 2 and 3 (each within the scatter of the next).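

In this assay, going by these compounds alone, the exchange of 4-chlorophenyl for 4-bromophenyl gives a 1.2-fold lower number from compound 1 to compound 4 (0.09 log units; within the scatter) and is the first step in this set that changes a single place. At this position on the aromatic ring, para to a large group, chloro and bromo therefore cannot be told apart on this read-out. The result speaks only to this one exchange between two halogens, and nothing available here gives a reason for it.

On these data alone, whether fluoro, an amine, a methoxy group or a carboxylic acid in place of the halogen would move the number beyond the scatter remains open. Also open is what the other chloro group, on the second aromatic ring of compound 1 and compound 4, contributes, as no pair shown changes it alone.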